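This account rests on a few compounds, and the source may have more. Where it says the series, first, only, none or still open, it means among the compounds named here.

Measured compounds in the series:

compound 1 `COc1ccc(-c2nnc(SCC(=O)c3ccccc3)n2-c2ccccc2)cc1OC`: 65%
compound 2 `C=CCn1c(SCC(=O)c2ccccc2)nnc1-c1ccc(OC)c(OC)c1`: 72%
compound 3 `C=CCn1c(SC/C(=N/O)c2ccccc2)nnc1-c1cc(OC)c(OC)c(OC)c1`: 73%

All three were read in a functional assay on the whole organism (strain albino) for inhibition, with Rattus norvegicus as the target, read by paw edema, with a stated time of 4 h, at a dose of 0.28 mmol/kg by the oral route; a lower number here means less inhibition, a higher number more inhibition at the dose given (going by the name of the read-out). In this assay compound 1 gives 65%, compound 2 gives 72% and compound 3 gives 73%; the three numbers lie within the usual scatter of one another, so no order among them is claimed.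

Compounds 2 and 1 differ in one place, (phenyl in place of allyl on an aromatic nitrogen). The step that goes with it is a number 7 percentage points lower from compound 2 to compound 1 (within the scatter).

How the core of compound 3 differs from the core of compound 2 is not broken down here; the two structures stand above.

The compound still to be measured is compound 4 `COc1cc(-c2nnc(SC/C(=N/O)c3ccccc3)n2-c2ccccc2)cc(OC)c1OC`. It differs from compound 3 by phenyl in place of allyl on an aromatic nitrogen. The surroundings of the place are described in the same words for both pairs, so this is the same change as the one from compound 2 to compound 1, and it occurs twice among the compounds shown.

For compound 4 in this assay the expected step is a number 7 percentage points lower from compound 3 to compound 4 (within the scatter), set beside the measured a number 7 percentage points lower from compound 2 to compound 1 (within the scatter); the expectation rests on that single earlier step, which stayed within the scatter, and on the value of compound 3, 73%. The estimate for compound 4 is therefore 66%, with a range from 52% to 78%.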

Compound 4, a percentage reported as inhibition, in the whole organism at one dose (the size of the read-out at that dose, not a potency): 76%
Compound 4: middle estimate off by 10 percentage points, on the low side, and the stated range covers the measured number.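

In this assay, phenyl in place of allyl on an aromatic nitrogen gives a number 3 percentage points higher from compound 3 to compound 4 (within the scatter), so on this second core the change again leaves the number within the scatter. Set beside the earlier step, the two results do not separate from each other: the same change on two cores in this assay, a number 7 percentage points lower (within the scatter) from compound 2 to compound 1 and a number 3 percentage points higher (within the scatter) from compound 3 to compound 4, 10 percentage points apart, within the scatter of two such steps

Across these two pairs, the swap from allyl to phenyl at this place can therefore be carried from one core to the other without a step that stands out from the scatter, but neither a direction nor a size can be assigned to it, and no claim of a true absence of effect follows from two pairs read at a single dose and a single time.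

As far as these compounds go, all four compounds carry allyl or phenyl on that aromatic nitrogen, so a longer saturated chain, or a chain ending in an amine or a carboxylic acid, remains open at this place. Compounds 1 and 2 carry a carbonyl and compounds 3 and 4 an oxime, but the two sets also differ in their methoxy groups, so the contribution of each of these differences cannot be read on its own.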